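The compounds below may be only part of what the source reports. "The series", "measured", "known", "first", "only" and "open" are said of these compounds alone.

Of the compounds shown here, three have so far been measured in an assay on membranes from Sf9 cells for displacement of a labelled ligand from histamine H2 receptor (Homo sapiens), read by scintillation counting, with a stated time of 60 min; a higher number here means a weaker inhibitor, a lower number a stronger inhibitor. Compound 1, `CCCNC(=O)/N=C(\N)Nc1cccc(-c2csc(N)n2)c1`, gives 5250 nM in this assay. Compound 2, `CCCCCCNC(=O)/N=C(\N)NC1CCc2nc(N)sc2C1`, gives 1120 nM in this assay. Compound 3, `Cc1nc(N)sc1CCCN/C(N)=N/C(=O)NC(C)c1ccc(OC(F)(F)F)cc1`, gives 126 nM in this assay, the lowest of the three numbers; its gap to compound 2 and its still wider gap to compound 1 both lie beyond the usual scatter, so compound 3 stands as the strongest inhibitor among the three.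

Compound 4, `Cc1nc(N)sc1CCCN/C(N)=N/C(=O)NC(C)c1ccc(Cl)cc1`, has not yet been measured. It differs from compound 3 in a single place: chloro in place of trifluoromethoxy on an aromatic carbon. Going by the values given here, no pair of measured compounds shows this same exchange, and compounds 1 and 2 differ from compound 3 in several places at once, so they offer no guide on this one change. With nothing in the measured set pointing firmly either way, the step is expected to be modest. In this assay the expected step is a 1.6-fold higher number from compound 3 to compound 4 (0.20 log units; within the scatter), leaning toward a slightly higher number but of a size that may not clearly exceed the scatter. Compound 4 is therefore estimated to give about 200 nM in this assay, within a range from 60 nM to 700 nM.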

Compound 4, inhibition constant: 46.8 nM
The estimate for compound 4 lay 4.3-fold (0.63 log units) above the measured number; measured number below the stated range.
By their numbers in this assay, from the lowest: compound 4; then compound 3; then compound 2; then compound 1.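

Going by these compounds alone, the exchange of trifluoromethoxy for chloro, on an aromatic carbon of a six-membered aromatic ring of carbon only and para to a large group, is the first change in this set that can be read on its own: in this assay it gives a 2.7-fold lower number from compound 3 to compound 4 (0.43 log units; beyond the scatter) and so lies beyond the scatter. This shows that the five heavy atoms of trifluoromethoxy, with its one hydrogen-bond acceptor, are not required at this position, since a single chlorine atom with no hydrogen-bond acceptor gives the lower number. Nothing at hand bears on why the number falls with this change.

With only these two groups compared at this position, the compounds shown do not tell whether the lower number belongs to chloro in particular or would also appear with fluoro, bromo, methyl, methoxy, an amine or plain hydrogen on that carbon. They also leave open whether the same exchange would lower the number with a different chain or on the core of another compound.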